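Removing the bromoethenyl carbonyl group from compound 2

A few compounds are considered here, and "the series" means these few. Any claim that something is new, unique, unknown or untested is made for them only; others in the source may bear on it.

Of the compounds shown here, three sharing one core have been measured in a functional assay on FM3A cells (Mus musculus) for antiproliferative activity, with a stated time of 48 h; on this read-out lower numbers stand for stronger inhibition and higher numbers for weaker inhibition. Compound 1 `C=C(Br)C(=O)Nc1ccc(/C=C/C(=O)c2ccc(I)cc2)cc1` gives 8300 nM, compound 3 `C=C(Br)C(=O)Nc1ccc(/C=C/C(=O)c2cccc(OC)c2)cc1` gives 2700 nM, and compound 2 `C=C(Br)C(=O)Nc1ccc(/C=C/C(=O)c2ccc(OC)cc2)cc1` gives 1200 nM, the lowest of the three numbers. Compound 4 `COc1ccc(C(=O)/C=C/c2ccc(N)cc2)cc1` differs from compound 2 in one place: hydrogen in place of (1-bromoethenyl)carbonyl on a nitrogen on an aromatic ring. This puts hydrogen in place of (1-bromoethenyl)carbonyl on a nitrogen on an aromatic ring. Among the measured compounds shown here, no measured step touches this group, so the evidence is indirect. The measured steps only exchange methoxy and iodo groups, and they remain modest: a 6.9-fold lower number from compound 1 to compound 2 (0.84 log units; beyond the scatter), a 3.1-fold lower number from compound 1 to compound 3 (0.49 log units; beyond the scatter) and a 2.3-fold higher number from compound 2 to compound 3 (0.35 log units; beyond the scatter). All three measured compounds carry the group that now leaves, so the data cannot show how the core behaves without it. Removing it is nevertheless a larger edit than any of those exchanges, and a clear rise from the value of compound 2, 1200 nM, is expected. The estimated change is a 13-fold higher number from compound 2 to compound 4 (1.10 log units; beyond the scatter). For compound 4 the expected value is 15000 nM, within an estimated range of 4000 nM to 50000 nM.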

Compound 4, half-maximal inhibitory concentration: 282000 nM
For compound 4 the middle estimate is 19-fold (1.27 log units) below the measured one, outside the stated range (above it).
By their numbers in this assay, from the lowest: compound 2; then compound 3; then compound 1; then compound 4.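

In this assay, the step to the free amino group gives a 240-fold higher number from compound 2 to compound 4 (2.37 log units; beyond the scatter), and this is far larger than any step among the methoxy and iodo exchanges. Among the compounds shown here, it is the first reading at this position on the nitrogen, and it shows that losing the whole (1-bromoethenyl)carbonyl group moves the number much further than changing the substituent on the other aromatic ring does. The material shown offers no measurement that explains the size of this step.

The compounds shown leave open which part of the departing group matters, as the bromine, the double bond and the carbonyl all leave together. An acetyl group or an unbrominated propenoyl group on the same nitrogen would tell these parts apart.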